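Swapping the Fluorophenyl Arm for a Chlorine

A few compounds are considered here, and "the series" means these few. Any claim that something is new, unique, unknown or untested is made for them only; others in the source may bear on it.

Compound 1 `Cc1c(-c2ccc(F)cc2)cc(C(=O)NC2CCCCCC2)c(=O)n1Cc1ccc(F)cc1` was tested in an assay on HEK293 cells for inhibition of Monoacylglycerol lipase ABHD6 (Homo sapiens), read by scintillation counting, with stated times of 30 min and 5 min (a higher number here means a weaker inhibitor, a lower number a stronger inhibitor), where compound 1 gives > 10000 nM, which is a limit of the assay and not a number. Compound 1 therefore stands at the limit, as the limit of > 10000 nM in this assay, at which 2 of the 3 values shown sit, shows. Compound 2 `COc1ccc(-c2cc(C(=O)NC3CCCCCC3)c(OCc3ccc(F)cc3)nc2C)cc1` gives 530 nM in this assay. Compound 3 `Cc1nc(OCc2ccc(F)cc2)c(C(=O)NC2CCCCCC2)cc1-c1ccc(F)cc1` gives > 10000 nM, again a limit. For the measured compounds named here, the only measured step, an at least 18-fold higher number from compound 2 to compound 3 (1.27 log units; beyond the scatter), concerns fluoro in place of methoxy and does not touch the change now considered. Compound 4 `Cc1c(Cl)cc(C(=O)NC2CCCCCC2)c(=O)n1Cc1ccc(F)cc1` differs from compound 1 by chloro in place of 4-fluorophenyl on an aromatic carbon. Going by the values given here, with no step of this kind measured, compound 4 is expected to remain near the limit, estimated at 20000 nM with a range from 5000 nM to 80000 nM. The expected step that the limit leaves unreadable from compound 1 to compound 4 is none beyond the scatter.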

Compound 4, half-maximal inhibitory concentration: > 10000 nM
Compound 4 gave a limit, no number; the forecaster's own chance of this, stated with the estimate: 80%; the middle value lies beyond the limit too.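

In this assay, compound 1 and compound 4 both give a limit rather than a number, and the change from 4-fluorophenyl to chloro cannot be read as a step. From the compounds shown here alone, how much that change matters for inhibition stays open.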